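A Furan-2-yl Replacement in a Series

The source may report more compounds than this note shows. Statements on the series, on what has been measured and on what is new or still open speak of the compounds shown alone.

Three measured compounds share one core and differ only in the group attached to an aromatic carbon of the five-membered aromatic ring with 1 sulfur, next to the ring sulfur. Compound 1 `CC(C)(C)Cc1c(-c2ccccn2)sc(N)c1C(=O)c1ccc(Cl)cc1` carries pyridin-2-yl there, and in an assay on CHO cells for displacement of a labelled ligand from adenosine receptor A3 (Homo sapiens), read by scintillation counting, tested at 10 uM (on this read-out lower numbers stand for less inhibition and higher numbers for more inhibition at the one concentration tested (going by the name of the read-out)), compound 1 gives 1%. Compound 2 `CC(C)(C)Cc1c(/C=C/c2ccc(Cl)cc2)sc(N)c1C(=O)c1ccc(Cl)cc1` carries 2-(4-chlorophenyl)ethenyl, and in this assay compound 2 gives 11%. Compound 3 `CC(C)(C)Cc1c(-c2cn[nH]c2)sc(N)c1C(=O)c1ccc(Cl)cc1` carries 1H-pyrazol-4-yl, and in this assay compound 3 gives 1%. Compound 3 stands level with compound 1 at the digits shown, the two together being the lowest of the three numbers; no change at the digits printed from compound 1 to compound 3 (within the scatter), while a number 10 percentage points lower from compound 2 to compound 3 (within the scatter).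

Compound 4 `CC(C)(C)Cc1c(-c2ccco2)sc(N)c1C(=O)c1ccc(Cl)cc1` differs from compound 3 in one place: furan-2-yl in place of 1H-pyrazol-4-yl on an aromatic carbon. For the measured compounds named here, the steps that bear on this exchange are the three at the same aromatic carbon: a number 10 percentage points higher from compound 1 to compound 2 (within the scatter), no change at the digits printed from compound 1 to compound 3 (within the scatter) and a number 10 percentage points lower from compound 2 to compound 3 (within the scatter). None of them moved the read-out beyond the usual scatter, whichever group stood in that position. Compound 4 is therefore expected to show a number 2 percentage points higher from compound 3 to compound 4 (within the scatter) in this assay, that is, no step beyond the scatter. For compound 4 the estimated value in this assay is 3%, with a range from 0% to 15%.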

Compound 4, a percentage reported as inhibition, at one concentration (the size of the read-out at that concentration, not a potency): 1%
Compound 4: the middle estimate sits 2 percentage points above what was measured; the measured number falls inside the stated range.
By their numbers in this assay, from the lowest: compounds 1, 3, 4 and 2 (each within the scatter of the next).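

Swapping 1H-pyrazol-4-yl for furan-2-yl keeps the count of 5 heavy atoms and the five-membered aromatic ring but takes away the hydrogen-bond donor and one ring hetero atom, and in this assay this exchange gives no change at the digits printed from compound 3 to compound 4 (within the scatter) with no effect that can be told from the scatter. The furan-2-yl group also stands level with the two other groups at this aromatic carbon next to the ring sulfur, with pyridin-2-yl (no change at the digits printed from compound 1 to compound 4 (within the scatter)) and with 2-(4-chlorophenyl)ethenyl (a number 10 percentage points lower from compound 2 to compound 4 (within the scatter)). The result adds a ring with oxygen as its only hetero atom, and a ring without the donor, to the groups tried here, and all four compounds remain within the scatter of one another in this assay.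

As far as these compounds go, whether any group at this position can move the read-out beyond the scatter stays open, for instance a carboxylic acid, a primary amine or a longer alkyl chain, as does the effect of exchanging the neopentyl group on the same core. No measurement at hand offers a reason for these flat numbers.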